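Trimming the quaternary methyl from the cyclopropyl substituent

This account rests on a few compounds, and the source may have more. Where it says the series, first, only, none or still open, it means among the compounds named here.

Compound 1 `O=C(Cn1nnc(-c2ccccc2)n1)NC1CC2CCC1C2` is the smallest member here; in an assay on HEK293 cells for activation of Kir3.1/Kir3.2 (Homo sapiens), read by thallium flux (a lower number here means a smaller maximal response, a higher number a larger maximal response), compound 1 gives 13%. Compound 2 `Cc1cc(NC(=O)Cn2nnc(-c3ccccc3)n2)n(C2CCCCC2)n1` carries the shared core with a methyl on an aromatic carbon, and in this assay compound 2 gives 92%. Compound 3 `CC1(c2cc(NC(=O)Cn3nnc(-c4ccccc4)n3)n(C3CCCCC3)n2)CC1` has 1-methylcyclopropyl in place of that methyl. For compound 3 this assay reports only a limit, > 10%, so compound 3 stands on a bound and not on a number, the bound being (the limit of > 10% in this assay, at which 1 of the 3 values shown sits). The step that the limit leaves unreadable from compound 2 to compound 3 is accordingly unreadable in size and direction.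

Compound 4 `O=C(Cn1nnc(-c2ccccc2)n1)Nc1cc(C2CC2)nn1C1CCCCC1` differs from compound 3 by hydrogen in place of methyl on a saturated ring carbon, that is 1-methylcyclopropyl to cyclopropyl. For the measured compounds named here, the only measured step touching this substituent is a step that the limit leaves unreadable from compound 2 to compound 3, which yields no size, so nothing quantitative carries over; the one fixed number is compound 2 at 92%. Compound 3 adds only its limit. Compound 4 is therefore expected, with wide uncertainty, to reach 50% in this assay, between 15% and 95%. The expected step that the limit leaves unreadable from compound 3 to compound 4 is estimated against a bound only and cannot be checked for direction.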

Compound 4, largest response reached (Emax), in percent of the reference or control that the assay uses: 45%
For compound 4 the middle estimate is 5 percentage points above the measured one, and the stated range covers the measured number.
By their numbers in this assay, from the lowest: compound 1; then compound 4; then compound 2.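

In this assay, cyclopropyl in place of methyl on an aromatic carbon gives a number 47 percentage points lower from compound 2 to compound 4 (beyond the scatter), the first readable size for a change at this position. This position is therefore not indifferent to the group it carries, although compound 4 still gives 45%, so the change lowers the maximal response without removing it. The steps to and from compound 3 cannot be read, since compound 3 stands only on a limit: the limit of > 10% in this assay, at which 1 of the 4 values shown sits.

Going by these compounds, whether the methyl on the saturated ring carbon of the three-membered ring raises or lowers the response therefore stays open. Also open, on these data alone, is how an ethyl, an isopropyl, a trifluoromethyl or an aminomethyl group on the same aromatic carbon would compare with methyl and cyclopropyl.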